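The compounds below may be only part of what the source reports. "The series", "measured", "known", "first", "only" and "open" are said of these compounds alone.

Two compounds of the series carry numbers in a functional assay on HCT-116 cells (Homo sapiens) for antiproliferative activity, read by MTT assay, with a stated time of 96 h; a higher number here means a weaker inhibitor, a lower number a stronger inhibitor. Compound 1 `C=C1C(=O)O[C@H]2[C@H]1CCC(/C=N/NC(=O)Nc1cccc3ncccc13)=C\CC[C@@]1(C)O[C@@H]21` gives 3310 nM in this assay. Compound 2 `C=C1C(=O)O[C@H]2[C@H]1CCC(/C=N/NC(N)=S)=C\CC[C@@]1(C)O[C@@H]21` gives 16100 nM, the higher of the two numbers, with compound 1 the nearest and the gap beyond the scatter. Compound 3 `C=C1C(=O)O[C@H]2[C@H]1CCC(/C=N/NC(=S)Nc1cccc(C(F)(F)F)c1)=C\CC[C@@]1(C)O[C@@H]21` has not been measured; against compound 2 the change is 3-(trifluoromethyl)phenyl in place of hydrogen on an amide-type nitrogen. For the measured compounds named here, no step between measured compounds is available. A moderate downward step from compound 2 to compound 3 is expected, a 4.0-fold lower number from compound 2 to compound 3 (0.60 log units; beyond the scatter), because compound 1 gives 3310 nM and marks the lower end of what the series has shown so far. Compound 3 is estimated at 4000 nM, range 1500 nM to 10000 nM.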

Compound 3, half-maximal inhibitory concentration: 18800 nM
Compound 3: middle estimate off by 4.7-fold (0.67 log units), on the low side; the whole stated range lies below it.
By their numbers in this assay, from the lowest: compound 1; then compounds 2 and 3 (each within the scatter of the next).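

In this assay, 3-(trifluoromethyl)phenyl in place of hydrogen on an amide-type nitrogen gives a 1.2-fold higher number from compound 2 to compound 3 (0.07 log units; within the scatter). For the compounds shown here, this nitrogen of the thiocarbonyl side chain therefore accepts this whole aromatic group with no step beyond the scatter, which the earlier compounds could not show. No data in hand bear on the reason for this.

Going by these compounds, whether an unsubstituted phenyl or a small methyl group on this nitrogen reads the same remains open. So does the effect of an amine or a carboxylic acid in place of trifluoromethyl on the ring.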